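A few compounds are considered here, and "the series" means these few. Any claim that something is new, unique, unknown or untested is made for them only; others in the source may bear on it.

Measured so far in an ADME assay on HepG2 cells (Homo sapiens) for cytotoxicity, read by fluorescence and resazurin assay, with a stated time of 24 h (on this read-out higher numbers stand for lower toxicity in this test and lower numbers for higher toxicity in this test), are these compounds
compound 1 `COc1ccccc1-c1nnc(SC2=CS(=O)(=O)c3ccccc32)o1` gives 16000 nM
compound 2 `COc1ccc(-c2nnc(SC3=CS(=O)(=O)c4ccccc43)o2)cc1` gives 22000 nM
compound 3 `COc1cccc(-c2nnc(SC3=CS(=O)(=O)c4ccccc43)o2)c1` gives 20000 nM

Compound 1 does not stand apart from the other two. Its steps are a 1.3-fold higher number from compound 1 to compound 3 (0.10 log units; within the scatter) and a 1.4-fold higher number from compound 1 to compound 2 (0.14 log units; within the scatter) and the remaining pair shows a 1.1-fold lower number from compound 2 to compound 3 (0.04 log units; within the scatter) as well, so the three numbers form a single cluster.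

Compound 4 `Cc1ccc(-c2nnc(SC3=CS(=O)(=O)c4ccccc43)o2)cc1` keeps the core of compound 1 and carries one change, 4-methylphenyl in place of 2-methoxyphenyl on an aromatic carbon with 4-methylphenyl in place of 2-methoxyphenyl on an aromatic carbon of the five-membered aromatic ring with 2 nitrogen and 1 oxygen. Within the data shown here, no measured step exchanges a methoxyphenyl for a methylphenyl, so the data hold no direct test of this swap. The nearest evidence is compound 2, which bears 4-methoxyphenyl and gives a 1.4-fold higher number from compound 1 to compound 2 (0.14 log units; within the scatter) in the series. None of the three steps lies beyond the scatter, so no step beyond the scatter is expected here, and no clear direction either. The expected change is a 1.3-fold higher number from compound 1 to compound 4 (0.10 log units; within the scatter) on this reasoning. For compound 4 the estimated half-maximal cytotoxic concentration is 20000 nM with an expected range of 9000 nM to 45000 nM in repeated measurements.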

Compound 4, half-maximal cytotoxic concentration: 31000 nM
Compound 4: the middle estimate sits 1.6-fold (0.19 log units) below what was measured; the measured number falls inside the stated range.
By their numbers in this assay, from the lowest: compounds 1, 3, 2 and 4 (each within the scatter of the next).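

In this assay the series now holds a direct test of methyl in place of methoxy on the phenyl group, and this exchange (a 1.4-fold higher number from compound 2 to compound 4 (0.15 log units; within the scatter)) stays within the scatter, so removing the oxygen from this substituent does not separate the two compounds on this read-out. Among these compounds, the two steps that change the substituent and its place on the phenyl group together (a 1.6-fold higher number from compound 3 to compound 4 (0.19 log units; within the scatter) and a 1.9-fold higher number from compound 1 to compound 4 (0.29 log units; within the scatter)) also remain within the scatter, although the second is the largest step seen so far, which means that 4-methylphenyl joins the three methoxyphenyl groups in one cluster at this position on the five-membered aromatic ring. Nothing available here speaks to the reason for any of these small steps.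

On these data alone, all four compounds carry a phenyl group with a single methyl or methoxy substituent, so it remains open whether an amine, a carboxylic acid or a chlorine on that phenyl group would give a step beyond the scatter. As far as these compounds go, it is equally open whether replacing the phenyl group with a longer alkyl chain, or altering the shared core, would move the number out of this cluster.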